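A few compounds are considered here, and "the series" means these few. Any claim that something is new, unique, unknown or untested is made for them only; others in the source may bear on it.

Of the compounds shown here, two have numbers so far. In a functional assay on K562 cells (Homo sapiens) for inhibition, read by MTT assay, with a stated time of 48 h (a higher number here means a weaker inhibitor, a lower number a stronger inhibitor), compound 1 `CC(C)(C)C(=O)Nc1ccc(-c2ccc(C(=O)N[C@H]3CN[C@@H](C(=O)Nc4ccc(Cl)c(C(F)(F)F)c4)C3)cc2)cn1` gives 11600 nM, the higher of the two; in this assay compound 2 `C[C@H](NC(=O)c1ccc(-c2ccc(N)nc2)cc1)C(=O)Nc1ccc(Cl)c(C(F)(F)F)c1` gives 5950 nM, and the gap between compound 1 and compound 2 lies within the scatter, so no order can be read from it. Compound 3 `Nc1ccc(-c2ccc(C(=O)N[C@H]3CN[C@@H](C(=O)Nc4ccc(Cl)c(C(F)(F)F)c4)C3)cc2)cn1` differs from compound 1 in one place: hydrogen in place of (tert-butyl)carbonyl on a nitrogen on an aromatic ring. For the measured compounds named here, no measured pair shows this change. The step of a 1.5-fold lower number from compound 1 to compound 3 (0.16 log units; within the scatter) is expected to stay within the scatter, with no clear direction. Compound 3 is estimated at 8000 nM, with a range from 3000 nM to 25000 nM.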

Compound 3, half-maximal inhibitory concentration: 9130 nM
Compound 3: the middle estimate sits 1.1-fold (0.06 log units) below what was measured; the measured number falls inside the stated range.
By their numbers in this assay, from the lowest: compounds 2, 3 and 1 (each within the scatter of the next).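

In this assay the exchange of (tert-butyl)carbonyl for hydrogen on this nitrogen gives the first step read at this position (a 1.3-fold lower number from compound 1 to compound 3 (0.10 log units; within the scatter)), and it lies within the scatter. At this position, the ((tert-butyl)carbonyl)amino and amino forms are therefore not told apart by this read-out. No measured evidence bears on the reason for this result.

Still open, as far as these compounds go, is whether a different group on this nitrogen, such as acetyl, methyl or a longer acyl chain, would give a step beyond the scatter. Replacing the amino group with a carboxylic acid also remains untested in the compounds shown.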